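A methyl step on a compound measured only by limits

The source may hold more compounds than are shown below. What is called first, only, known or untested is meant among the compounds shown, and "the series" means these compounds.

In a functional assay on MT4 cells (Homo sapiens) for cytotoxicity (on this read-out higher numbers stand for weaker inhibition and lower numbers for stronger inhibition), compound 1 (`N#Cc1c(N)cccc1S(=O)(=O)c1ccccc1`) gives > 5000 nM as its result, which is a limit and not a number. Compound 2 (`COc1cccc(S(=O)(=O)c2cccc(N)c2C#N)c1`) gives > 200000 nM as its result, again a limit. Compound 3 (`Cc1ccccc1S(=O)(=O)c1cccc(N)c1C#N`) gives > 200000 nM as its result, also a limit. No exact number is therefore available for any of the three, and compound 1 can only be placed by its limit.

Compound 4 (`Cc1ccc(S(=O)(=O)c2cccc(N)c2C#N)cc1`) has not yet been measured. It differs from compound 1 by a single change, (methyl in place of hydrogen on an aromatic carbon), a methyl in place of hydrogen on an aromatic carbon, para to a large group.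

Among the compounds with values here, two measured steps bear on this change. The closer one is a step that the two limits leave unreadable from compound 1 to compound 3, which also places a methyl on an aromatic carbon. The other is a step that the two limits leave unreadable from compound 1 to compound 2, which places a methoxy there. Neither step has a size that can be read, so any forecast is rough.

The nearest guide is compound 3 with > 200000 nM as its limit, and the same kind of result is expected here. The expected change is a step that the limit leaves unreadable from compound 1 to compound 4 toward higher numbers, meaning weaker inhibition. Compound 4 is expected near 200000 nM, with an estimated range from 40000 nM to 400000 nM in this measurement.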

Compound 4, half-maximal inhibitory concentration: > 200000 nM
Compound 4 gave a limit, no number; the forecaster's own chance of this, stated with the estimate: 80%; the middle value lies on the limit itself.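

Compound 1 gives > 5000 nM, which is a limit. Compound 4 gives > 200000 nM, also a limit. No size can be read for the methyl step between compound 1 and compound 4. The compounds shown leave open what exact number any of these four compounds would give in this assay.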